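From a dichlorophenyl carbonyl cap to methylsulfonyl

A few compounds are considered here, and "the series" means these few. Any claim that something is new, unique, unknown or untested is made for them only; others in the source may bear on it.

Of the compounds shown here, three have been measured in a functional assay on HCC1806 cells (Homo sapiens) for inhibition, read by sulforhodamine B assay, tested at 10 uM; on this read-out higher numbers stand for more inhibition at the one concentration tested (going by the name of the read-out) and lower numbers for less inhibition. Compound 1 `CN1CCN(c2ccc(C3=NN(S(C)(=O)=O)C(c4ccc(N(C)C)cc4)C3)cc2)CC1` gives -18.5%, compound 2 `CN(C)c1ccc(C2CC(c3ccc(-n4cncn4)cc3)=NN2S(C)(=O)=O)cc1` gives 10.8%, and compound 3 `CN(C)c1ccc(C2CC(c3ccc(-n4ccnc4)cc3)=NN2C(=O)c2cc(Cl)cc(Cl)c2)cc1` gives 44.5%, the highest of the three, with compound 2 nearest to it and compound 1 furthest. Going by the values given here, the only measured step, a number 29.3 percentage points higher from compound 1 to compound 2 (beyond the scatter), alters a group on an aromatic carbon and leaves the ring nitrogen untouched. Compound 4 `CN(C)c1ccc(C2CC(c3ccc(-n4ccnc4)cc3)=NN2S(C)(=O)=O)cc1` differs from compound 3 by methylsulfonyl in place of (3,5-dichlorophenyl)carbonyl on an amine nitrogen in a ring. Among the compounds with values here, no measured step bears on this exchange, yet compounds 1 and 2 both carry methylsulfonyl at the ring nitrogen and both sit far below compound 3. Compound 4 is therefore expected to shift by a number 29.5 percentage points lower from compound 3 to compound 4 (beyond the scatter). For compound 4 the estimate is 15%, with a range from -5% to 35%.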

Compound 4, a percentage reported as inhibition, at one concentration (the size of the read-out at that concentration, not a potency): 11.3%
Compound 4: middle estimate off by 3.7 percentage points, on the high side, within the range that was stated.
By their numbers in this assay, from the lowest: compound 1; then compounds 2 and 4 (each within the scatter of the next); then compound 3.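

In this assay, the exchange on the ring nitrogen is now measured directly with the 1H-imidazol-1-yl group held constant, and the change to methylsulfonyl is large (a number 33.2 percentage points lower from compound 3 to compound 4 (beyond the scatter)). With methylsulfonyl in place, the two azole groups cannot be told apart (a number 0.5 percentage points higher from compound 2 to compound 4 (within the scatter)), while 1H-imidazol-1-yl stands clear of 4-methylpiperazin-1-yl (a number 29.8 percentage points higher from compound 1 to compound 4 (beyond the scatter)). Nothing given here explains the loss on exchanging the cap. As far as these compounds go, whether an acetyl or unsubstituted benzoyl group on this nitrogen would match compound 3 remains open, as does how 4-methylpiperazin-1-yl would behave alongside the (3,5-dichlorophenyl)carbonyl group.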